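Cyclohexyl for cyclopentyl in an antiproliferative series

A few compounds are considered here, and "the series" means these few. Any claim that something is new, unique, unknown or untested is made for them only; others in the source may bear on it.

In a functional assay on MCF7 cells (Homo sapiens) for antiproliferative activity, read by MTT assay, with a stated time of 24 h (on this read-out higher numbers stand for weaker inhibition and lower numbers for stronger inhibition), compound 1 (`CCN(CC)CCNC(=O)C1CC=C(C(CC)(CC)c2ccc(C#CC(C)(C)O)c(C)c2)N1CC`) gives 1490 nM and compound 2 (`CCN(CC)CCNC(=O)C1CC=C(C(CC)(CC)c2ccc(C#CC(O)C3CCCC3)c(C)c2)N1CC`) gives 1580 nM as its reading, which places these two compounds within the scatter of each other. Compound 3 (`CCN(CC)CCNC(=O)C1CC=C(C(CC)(CC)c2ccc(C#CC(O)C3CCCCC3)c(C)c2)N1CC`) carries cyclohexyl in place of cyclopentyl on a saturated chain carbon bound to an oxygen on a saturated carbon and a triple-bonded carbon. Among the measured compounds shown here, one measured step bears on this change: a 1.1-fold higher number from compound 1 to compound 2 (0.03 log units; within the scatter) came from putting cyclopentyl(hydroxy)methyl in place of 1-hydroxy-1-methylethyl on a triple-bonded carbon. For the measured compounds named here, that step altered the same group and stayed within the scatter, but it is the only guide available. The step expected in this assay is a 1.1-fold lower number from compound 2 to compound 3 (0.02 log units; within the scatter) and so none beyond the scatter, in either direction. Compound 3 is estimated at 1500 nM with 800 nM to 2800 nM as the expected range.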

Compound 3, half-maximal inhibitory concentration: 2790 nM
Beside the measured number, compound 3's estimate is 1.9-fold (0.27 log units) below it, and the stated range covers the measured number.
By their numbers in this assay, from the lowest: compounds 1, 2 and 3 (each within the scatter of the next).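

In this assay, among the compounds shown here, the ring on the saturated chain carbon bound to an oxygen on a saturated carbon and a triple-bonded carbon was changed for the first time, and cyclohexyl in place of cyclopentyl gave a 1.8-fold higher number from compound 2 to compound 3 (0.25 log units; within the scatter). Measured against the 1-hydroxy-1-methylethyl group of the first compound, cyclohexyl(hydroxy)methyl gave a 1.9-fold higher number from compound 1 to compound 3 (0.27 log units; within the scatter), so neither the five-membered nor the six-membered carbon ring moves the reading beyond the scatter. Nothing shown explains these readings.

As far as these compounds go, all three compounds keep the hydroxyl-bearing carbon on the triple bond and carry only carbon groups there, so the effect of an amine or a carboxylic acid at this place remains open. From the compounds shown here alone, it is also open whether a longer chain in place of cyclohexyl would stay within the scatter in this assay.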